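Aminopyrimidine series: pyridinyl to chlorophenyl on the chain carbon

The source may hold more compounds than are shown below. What is called first, only, known or untested is meant among the compounds shown, and "the series" means these compounds.

Measured compounds:
compound 1 `CN(C)c1nc(NCC2CC2)cc(-c2ccccn2)n1`, > 25000 nM
compound 2 `CNc1nc(NC2(c3ccc(Cl)cc3)CCC2)cc(-c2ccccn2)n1`, 25 nM
compound 3 `CNc1nc(NCc2ccncc2)cc(-c2ccccn2)n1`, 87 nM

In a functional assay on HEK293 cells for agonist activity at G-protein coupled receptor 39 (Homo sapiens), read by inositol phosphate accumulation (on this read-out higher numbers stand for an effect only at larger amounts of compound and lower numbers for an effect already at smaller amounts), compound 1 reaches only a limit of the assay, > 25000 nM; see (the limit of > 25000 nM in this assay, at which 1 of the 3 values shown sits). Compound 2 gives 25 nM and compound 3 gives 87 nM, the highest of the two numbers, with compound 2 sitting beyond the scatter below it.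

Compound 4 `CNc1nc(NCc2ccc(Cl)cc2)cc(-c2ccccn2)n1` is not yet measured in this assay. Its change from compound 3: 4-chlorophenyl in place of pyridin-4-yl on a saturated chain carbon bound to a nitrogen on an aromatic ring. Among the measured compounds shown here, no measured step covers this change; a modest shift toward a lower number is expected, since compound 2 with 25 nM also carries a 4-chlorophenyl. For compound 4 the estimate in this assay is 50 nM, between 15 nM and 200 nM, a step of a 1.7-fold lower number from compound 3 to compound 4 (0.24 log units; within the scatter) that is expected to stay near the scatter.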

Compound 4, half-maximal effective concentration: 15 nM
Compound 4: the middle estimate sits 3.3-fold (0.52 log units) above what was measured; the range from low to high includes it.
By their numbers in this assay, from the lowest: compounds 4 and 2 (each within the scatter of the next); then compound 3. At a limit, above all of these: compound 1.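

In this assay, 4-chlorophenyl in place of pyridin-4-yl on a saturated chain carbon bound to a nitrogen on an aromatic ring gives a 5.8-fold lower number from compound 3 to compound 4 (0.76 log units; beyond the scatter). Among the compounds shown here, this is the first readable step, and it shows that the aromatic ring at this position affects the number, though it removes the ring nitrogen and adds the chlorine together. No measurement at hand accounts for the step.

A plain phenyl here would separate those two parts of the change. From the compounds shown here alone, whether a 4-fluorophenyl or a 4-methoxyphenyl would match compound 4 remains open.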